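Methylating the phenol of compound 1: an expectation

The compounds below may be only part of what the source reports. "The series", "measured", "known", "first", "only" and "open" are said of these compounds alone.

Compound 1, `O=C(Nc1cccc(-n2cc(-c3ccncc3)c(-c3cc(O)cc(Cl)c3)n2)c1)Nc1ccc(Cl)c(C(F)(F)F)c1`: 107%
Compound 2, `O=C(Nc1cccc(-n2cc(-c3ccncc3)c(-c3cc(O)cc(Cl)c3)n2)c1)Nc1ccc(Cl)c(Cl)c1`: 52%

Of the compounds shown here, two have been measured in a functional assay on NCI-H322M cells (Homo sapiens) for inhibition, read by sulforhodamine B assay, with a stated time of 48 h, tested at 0.01 uM; a higher number here means a weaker effect of the compound at the concentration tested, a lower number a stronger effect. Compound 1 gives 107%, the highest of the two numbers. Compound 2 gives 52%. Within the data shown here, the single measured step, a number 55 percentage points lower from compound 1 to compound 2 (beyond the scatter), changes the aryl group on the urea side of the molecule.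

Compound 3 `COc1cc(Cl)cc(-c2nn(-c3cccc(NC(=O)Nc4ccc(Cl)c(C(F)(F)F)c4)c3)cc2-c2ccncc2)c1` differs from compound 1 by methyl in place of hydrogen on an oxygen on an aromatic ring. Among the measured compounds shown here, the step from compound 1 to compound 2 alters a different part of the molecule and so does not bear on this change; no measured step touches the oxygen on the aromatic ring. With nothing in the measured data to point either way, the expectation for compound 3 is a step of a number 7 percentage points lower from compound 1 to compound 3 (within the scatter), that is, no change beyond the scatter. Compound 3 is therefore estimated at 100%, within 70% to 120%.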

Compound 3, a percentage reported as activity, at one concentration (the size of the read-out at that concentration, not a potency): 96%
Estimate against measurement, compound 3: 4 percentage points above; the range from low to high includes it.
By their numbers in this assay, from the lowest: compound 2; then compound 3; then compound 1.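

In this assay, the oxygen on the aromatic ring now has a measured change of its own, with a number 11 percentage points lower from compound 1 to compound 3 (beyond the scatter) on replacing hydroxy by methoxy, a modest move towards a stronger effect. The hydrogen on this oxygen is therefore not needed for the effect seen at this concentration, and the position accepts a methyl while the read-out stays in the same upper region. Nothing measured on these compounds accounts for the step.

On these data alone, whether the same change would give a step of similar size with the dichlorophenyl urea of compound 2 remains open. So does the outcome of placing a longer chain such as ethoxy on this oxygen, or of an amine in place of the hydroxy.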